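From sec-butyl to a protected aminobutyl side chain

This account rests on a few compounds, and the source may have more. Where it says the series, first, only, none or still open, it means among the compounds named here.

Compound 2 `CC[C@H](C)[C@H](NC(=O)CN(c1ncnc2c1ncn2C1CCCCO1)C1CC1)C(=O)OCc1ccccc1` gives 20.4% in a functional assay on the whole organism (Tail, strain ICR) with Mus musculus as the target, in the tail flick test, with a stated time of 120 min, at a dose of 25 umol/kg by the oral route (a higher number here means a stronger effect of the compound at the dose given, a lower number a weaker effect), the second highest of the three numbers measured. Compound 1 `NC(=O)CC[C@H](NC(=O)CN(c1ncnc2c1ncn2C1CCCCO1)C1CC1)C(=O)OCc1ccccc1` gives 22.3%, which lies within the scatter of compound 2, while compound 3 `CSCC[C@H](NC(=O)CN(c1nc(Cl)nc2[nH]cnc12)C1CC1)C(=O)O` gives 5.67%, a number beyond the scatter below compound 2. Compound 4 `CC(C)(C)OC(=O)NCCCC[C@H](NC(=O)CN(c1ncnc2c1ncn2C1CCCCO1)C1CC1)C(=O)OCc1ccccc1` differs from compound 2 by 4-((tert-butoxycarbonyl)amino)butyl in place of sec-butyl on a saturated chain carbon bound to an amide-type nitrogen and a carbonyl carbon. Going by the values given here, the one measured step at this same place is a number 1.9 percentage points lower from compound 1 to compound 2 (within the scatter), where exchanging one side chain for a quite different one left the read-out within the scatter. On that evidence no step beyond the scatter is expected a number 0.4 percentage points lower from compound 2 to compound 4 (within the scatter). Compound 4 is therefore expected to give 20%, with a range from 8% to 32%.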

Compound 4, a percentage reported as activity, at one dose (the size of the read-out at that dose, not a potency): 28.4%
Compound 4: the middle estimate sits 8.4 percentage points below what was measured; low and high end bracket the measured number.
By their numbers in this assay, from the lowest: compound 3; then compounds 2, 1 and 4 (each within the scatter of the next).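

In this assay the saturated chain carbon bound to an amide-type nitrogen and a carbonyl carbon accepts a far larger side chain: 4-((tert-butoxycarbonyl)amino)butyl, with its 12 heavy atoms, replaces sec-butyl, with its 4 heavy atoms, giving a number 8 percentage points higher from compound 2 to compound 4 (within the scatter). Against the side chain of compound 1 the result is the same, with a number 6.1 percentage points higher from compound 1 to compound 4 (within the scatter), so all three side chains lie within the scatter of one another. Nothing available explains this insensitivity. As far as these compounds go, it remains open whether 4-aminobutyl, with the free amine, or a side chain carrying a carboxylic acid would hold the read-out at this level.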